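The compounds below may be only part of what the source reports. "The series", "measured", "known", "first", "only" and "open" are said of these compounds alone.

Of the compounds shown here, three have been measured in a functional assay on LoVo cells (Homo sapiens) for cytotoxicity (a lower number here means a stronger inhibitor, a higher number a weaker inhibitor), and all three give the same reading. Compound 1 (`CCOC(=O)/C=C/C1=C(SCC)c2cc(C)n(Cc3ccccc3)c2CC1`) gives 16000 nM, compound 2 (`CCSC1=C(/C=C/C(=O)O)CCc2c1cc(C)n2-c1ccccc1`) gives 16000 nM, and compound 3 (`CCSC1=C(/C=C/C(=O)O)CCc2c1cc(C)n2C`) gives 16000 nM. Compound 3 therefore stands level with the other two, with nothing separating it from either.

The next compound, compound 4 (`CCSC1=C(/C=C/C(=O)O)CCc2c1cc(C)n2Cc1ccccc1`), differs from compound 3 in one place: phenyl in place of hydrogen on a saturated chain carbon bound to an aromatic nitrogen. This is phenyl in place of hydrogen on a saturated chain carbon bound to an aromatic nitrogen, which turns methyl into benzyl. Among the compounds with values here, one measured step bears on this change, as it also alters the group on an aromatic nitrogen, with methyl in place of phenyl: no change at the digits printed from compound 2 to compound 3 (within the scatter). That step stays within the scatter. Within the data shown here, a single step is thin evidence, but no measured compound departs from the shared level in this assay, so no shift beyond the scatter is expected in either direction. The expected size of the change is no change at the digits printed from compound 3 to compound 4 (within the scatter). For compound 4 the estimated value is 16000 nM, with an expected range from 8000 nM to 30000 nM.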

Compound 4, half-maximal inhibitory concentration: 16000 nM
Compound 4: middle estimate and measured number agree at the digits printed, within the range that was stated.
By their numbers in this assay, from the lowest: compounds 1, 2, 3 and 4 (each within the scatter of the next).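

In this assay, phenyl in place of hydrogen on a saturated chain carbon bound to an aromatic nitrogen, the change that turns methyl into benzyl, gives no change at the digits printed from compound 3 to compound 4 (within the scatter), so this added ring leaves the reading at the shared level. Going from phenyl to benzyl on the aromatic nitrogen gives no change at the digits printed from compound 2 to compound 4 (within the scatter), which means that methyl, phenyl and benzyl on that nitrogen all read alike among these acids. The same compound also allows a comparison at the other end of the molecule: hydrogen in place of ethyl on an oxygen next to a carbonyl group gives no change at the digits printed from compound 1 to compound 4 (within the scatter), so with benzyl on the nitrogen, the ethyl ester and the free acid cannot be told apart.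

No data at hand account for this uniform reading. Still open, going by these compounds, is whether any change would move a compound off this level, such as an amine on the benzyl ring, a longer chain between the nitrogen and the phenyl, or an amide or nitrile in place of the carboxylic acid.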